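A few compounds are considered here, and "the series" means these few. Any claim that something is new, unique, unknown or untested is made for them only; others in the source may bear on it.

Compound 2 `C=CC(=C)CC[C@@H]1[C@@]2(C)CCC[C@](C)(COC(=O)/C=C/c3ccc(O)cc3)[C@@H]2CC[C@@]1(C)O` is a cinnamate-type ester of a diterpenoid alcohol. In a functional assay on SMMC-7721 cells (Homo sapiens) for cytotoxicity, read by MTT assay, with a stated time of 48 h (on this read-out higher numbers stand for weaker inhibition and lower numbers for stronger inhibition), compound 2 gives 15500 nM, the lowest of the two numbers reported, while its geometric partner compound 1 `C=CC(=C)CC[C@@H]1[C@@]2(C)CCC[C@](C)(COC(=O)/C=C\c3ccc(O)cc3)[C@@H]2CC[C@@]1(C)O` gives 16200 nM. The step of a 1.0-fold lower number from compound 1 to compound 2 (0.02 log units; within the scatter) rests on the fact (the fact that compounds 1 and 2 differ only in the configuration as drawn), so the drawn double-bond geometry leaves the read-out unchanged within the scatter. Compound 3 `C=C1CC[C@@H]2[C@](C)(CCC[C@]2(C)C(=O)O)[C@H]1C/C=C(\C)C=O` returns only a limit, > 40000 nM, and the evidence the limit of > 40000 nM in this assay, at which 1 of the 3 values shown sits, marks it as such.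

Compound 4 `C=CC(=C)CC[C@@H]1[C@@]2(C)CCC[C@](C)(COC(=O)/C=C/c3ccc(O)c(OC)c3)[C@@H]2CC[C@@]1(C)O` differs from compound 2 by methoxy in place of hydrogen on an aromatic carbon. Going by the values given here, no measured pair in this set changes the aromatic ring in this way; the only step with both ends measured is the within-scatter one between compound 1 and compound 2, which says nothing about substitution on the ring. Among the compounds with values here, with no step bearing on the change, the expectation for compound 4 is a step of a 1.0-fold lower number from compound 2 to compound 4 (0.01 log units; within the scatter) that stays within the scatter. Compound 4 is therefore estimated at 15000 nM, with a range from 6000 nM to 38000 nM.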

Compound 4, half-maximal inhibitory concentration: 14100 nM
Beside the measured number, compound 4's estimate is 1.1-fold (0.03 log units) above it; measured number inside the range.
By their numbers in this assay, from the lowest: compounds 4, 2 and 1 (each within the scatter of the next). At a limit, above all of these: compound 3.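

Going by these compounds alone, until this result, no measured pair touched the aromatic ring. In this assay, methoxy in place of hydrogen on an aromatic carbon, ortho to a hydroxy group, gives a 1.1-fold lower number from compound 2 to compound 4 (0.04 log units; within the scatter), so this position takes the added group without the read-out leaving the scatter. The wider reading of the same change, 2-(4-hydroxy-3-methoxyphenyl)ethenyl in place of 2-(4-hydroxyphenyl)ethenyl, gives a 1.1-fold lower number from compound 1 to compound 4 (0.06 log units; within the scatter), which also stays within the scatter, and nothing at hand explains why the read-out holds.

As far as these compounds go, it remains open whether an amine, a carboxylic acid or a longer chain such as ethoxy at this position would move the read-out beyond the scatter. Also open, from the compounds shown here alone, is what replacing the hydroxy group on this ring would do.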